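Compound 4: methoxy for hydrogen on the phenyl

A few compounds are considered here, and "the series" means these few. Any claim that something is new, unique, unknown or untested is made for them only; others in the source may bear on it.

Compound 3 `CC(C)=CCOc1cc(O)c2c(c1)OC(c1ccccc1)CC2=O` gives 7320 nM in a functional assay (on this read-out lower numbers stand for stronger inhibition and higher numbers for weaker inhibition), the highest of the three numbers measured, though its gaps to compound 1 `CC(C)=CCOc1ccc2c(c1)OC(c1ccccc1)CC2=O` at 6070 nM and to compound 2 `CC(C)=CCOc1ccc2c(c1)OC(c1ccc(Cl)cc1Cl)CC2=O` at 5260 nM both lie within the scatter. Compound 4 `COc1ccc(C2CC(=O)c3c(O)cc(OCC=C(C)C)cc3O2)cc1` differs from compound 3 by methoxy in place of hydrogen on an aromatic carbon. The measured step that bears on it most is the earlier change at the same phenyl, a 1.2-fold lower number from compound 1 to compound 2 (0.06 log units; within the scatter); the other step, a 1.2-fold higher number from compound 1 to compound 3 (0.08 log units; within the scatter), concerns a different ring. Neither moved the read-out beyond the scatter, so no step beyond the scatter is expected here in either direction; the expected step is a 1.0-fold lower number from compound 3 to compound 4 (0.02 log units; within the scatter). Compound 4 is therefore estimated at 7000 nM in this assay, within 3500 nM to 14000 nM.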

Compound 4, half-maximal inhibitory concentration: 5080 nM
Compound 4: middle estimate off by 1.4-fold (0.14 log units), on the high side; low and high end bracket the measured number.
By their numbers in this assay, from the lowest: compounds 4, 2, 1 and 3 (each within the scatter of the next).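

In this assay the change from phenyl to 4-methoxyphenyl gives a 1.4-fold lower number from compound 3 to compound 4 (0.16 log units; within the scatter) and so stays within the scatter, which shows that this aromatic carbon, para to a large group, accepts methoxy without a clear change when the hydroxy of compound 3 is present. Together with a 1.2-fold lower number from compound 1 to compound 2 (0.06 log units; within the scatter) this gives two substitutions on the phenyl, neither beyond the scatter. No measurement offers an explanation for the size of this step.

Still open, on these data alone, is whether an amine, a carboxylic acid or a longer alkoxy chain on the same carbon would move the number beyond the scatter.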